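A few compounds are considered here, and "the series" means these few. Any claim that something is new, unique, unknown or untested is made for them only; others in the source may bear on it.

Among the compounds with values here, the three compounds measured so far carry different acyl groups on the same amide nitrogen of a shared core. In an assay on CHO cells for displacement of a labelled ligand from histamine receptor H3 (Macaca mulatta) (a higher number here means a weaker inhibitor, a lower number a stronger inhibitor), compound 1 `CC(=O)N1CCCC1C(=O)Nc1ccc(N2CCC(N3CCCC3C)C2)cc1` gives 14.1 nM, and compound 3 `Cc1cc(N2CCC(N3CCCC3C)C2)ccc1NC(=O)C1CC1` gives 9.6 nM in this assay. Compound 2 `Cc1cc(N2CC[C@H](N3CCC[C@@H]3C)C2)ccc1NC(=O)C1C(C)(C)C1(C)C` gives 0.55 nM in this assay, the lowest of the three numbers: its nearest neighbour is compound 3, whose number stands well beyond the scatter above it, and compound 1 lies further still. Compound 2 is thus the strongest inhibitor of the three.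

The next compound, compound 4 `Cc1cc(N2CC[C@H](N3CCC[C@@H]3C)C2)ccc1NC(=O)C1CCOCC1`, keeps everything else of compound 2 and alters only the acyl group: oxan-4-yl in place of 2,2,3,3-tetramethylcyclopropyl on a carbonyl carbon. Both acyl groups are non-aromatic rings joined through a carbonyl, but the ring that leaves is the small, fully methylated one, while the ring that enters is larger and carries an oxygen.

Within the data shown here, no measured pair shows this exact exchange, so the expectation rests on what the three numbers show. Compound 3, with a plain three-membered ring on the carbonyl, gives 9.6 nM in this assay, and compound 4 is expected to land closer to that value than to compound 2. The estimate for compound 4 is therefore 5 nM in this assay, with a range from 1.5 nM to 15 nM, meaning an expected step of a 9.1-fold higher number from compound 2 to compound 4 (0.96 log units; beyond the scatter), a weakening beyond the scatter.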

Compound 4, inhibition constant: 0.97 nM
Estimate against measurement, compound 4: 5.2-fold (0.71 log units) above; the whole stated range lies above it.
By their numbers in this assay, from the lowest: compounds 2 and 4 (each within the scatter of the next); then compounds 3 and 1 (each within the scatter of the next).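

In this assay, putting oxan-4-yl in place of 2,2,3,3-tetramethylcyclopropyl on a carbonyl carbon gives a 1.8-fold higher number from compound 2 to compound 4 (0.25 log units; within the scatter), so the two acyl groups cannot be told apart in this assay. Within the data shown here, this is the first exchange at this place that can be read with the rest of the molecule held fixed, and it shows that the fully methylated three-membered ring is not required for a number in this range: a six-membered ring carrying an oxygen gives a value within the scatter of it. Nothing measured here accounts for this result.

Going by these compounds, it remains open whether the ring oxygen of compound 4 matters at all, which a cyclohexyl group would test directly, and whether a piperidin-4-yl group, with an amine nitrogen in the place of that oxygen, would give a similar number. On these data alone, it also remains open how far this place accepts other kinds of acyl group on the same core, such as a phenyl ring or an open chain like tert-butyl.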